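This account rests on a few compounds, and the source may have more. Where it says the series, first, only, none or still open, it means among the compounds named here.

Series values so far, from a functional assay on QGY-7703 cells (Homo sapiens) for cytotoxicity, read by MTT assay, with a stated time of 24 h; a higher number here means a weaker inhibitor, a lower number a stronger inhibitor:

- compound 1 `CC(=O)Nc1ccc(S(=O)(=O)N2C/C(=C\c3cccc([N+](=O)[O-])c3)C(=O)/C(=C/c3cccc([N+](=O)[O-])c3)C2)cc1`: 6760 nM
- compound 2 `COc1cc(/C=C2\CN(S(=O)(=O)c3ccc(NC(C)=O)cc3)C/C(=C\c3cc(OC)c(OC)c(OC)c3)C2=O)cc(OC)c1OC`: 1900 nM
- compound 3 `CC(=O)Nc1ccc(S(=O)(=O)N2C/C(=C\c3cccc([N+](=O)[O-])c3)C(=O)/C(=C/c3ccccc3F)C2)cc1`: 7850 nM

Compound 3 sits within the scatter of compound 1, as shown by a 1.2-fold higher number from compound 1 to compound 3 (0.06 log units; within the scatter). Compound 2, at 1900 nM, has a lower number than either, beyond the scatter.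

The next compound to read is compound 4 `COc1cc(/C=C2\CN(S(=O)(=O)c3ccc(NC(C)=O)cc3)C/C(=C\c3cccc([N+](=O)[O-])c3)C2=O)cc(OC)c1OC`. Its difference from compound 3 is 3,4,5-trimethoxyphenyl in place of 2-fluorophenyl on a double-bonded chain carbon bound to a double-bonded ring carbon. In short, 3,4,5-trimethoxyphenyl comes in place of 2-fluorophenyl on a double-bonded chain carbon bound to a double-bonded ring carbon.

Among the measured compounds shown here, only one measured step touches this place: a 1.2-fold higher number from compound 1 to compound 3 (0.06 log units; within the scatter), where 2-fluorophenyl replaced 3-nitrophenyl and the number stayed within the scatter. For the measured compounds named here, no measured step shows the entering group alone. The nearest guide is therefore the pair of values at the two ends. Compound 4 carries one 3-nitrophenyl, as in compound 1 at 6760 nM, and one 3,4,5-trimethoxyphenyl, as in compound 2 at 1900 nM. A value between those two is the working expectation.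

In this assay the expected change is a modest fall in the number, a 2.2-fold lower number from compound 3 to compound 4 (0.34 log units; beyond the scatter). The upper part of the range still allows no real change. For compound 4 the estimated value is 3600 nM, with an expected range of 1700 nM to 7500 nM.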

Compound 4, half-maximal inhibitory concentration: 2550 nM
The estimate for compound 4 lay 1.4-fold (0.15 log units) above the measured number, and the stated range covers the measured number.
By their numbers in this assay, from the lowest: compounds 2 and 4 (each within the scatter of the next); then compounds 1 and 3 (each within the scatter of the next).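

In this assay, one 3,4,5-trimethoxyphenyl on a double-bonded chain carbon bound to a double-bonded ring carbon now reads on its own, and the number falls beyond the scatter whichever group it replaces: 2-fluorophenyl (a 3.1-fold lower number from compound 3 to compound 4 (0.49 log units; beyond the scatter)) or 3-nitrophenyl (a 2.7-fold lower number from compound 1 to compound 4 (0.42 log units; beyond the scatter)), both modest steps. The second 3,4,5-trimethoxyphenyl of compound 2 shows no separate contribution, as putting 3-nitrophenyl in its place stays within the scatter (a 1.3-fold higher number from compound 2 to compound 4 (0.13 log units; within the scatter)), so among these four compounds a single such group is enough to reach the lower pair of numbers, and no compound shown goes against this. The data in hand give no measured basis for explaining these shifts.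

Still open, as far as these compounds go, is whether the fall needs all three methoxy groups, or whether a phenyl carrying fewer of them, or a hydroxy group in their stead, would read the same at this place. Also open, from the compounds shown here alone, is how a phenyl bearing a dimethylamino group or a carboxylic acid would read here, and whether the single 3,4,5-trimethoxyphenyl holds its effect with 2-fluorophenyl as the partner group.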